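This account rests on a few compounds, and the source may have more. Where it says the series, first, only, none or still open, it means among the compounds named here.

Of the compounds shown here, three that share one core have been measured in a functional assay on HTB-54 cells (Homo sapiens) for cytotoxicity, read by MTT assay, with a stated time of 72 h; a higher number here means a weaker inhibitor of growth, a lower number a stronger inhibitor of growth. Compound 1 `CCCOC(=O)Nc1ccc([Se]C#N)cc1` gives 28900 nM. Compound 2 `N#C[Se]c1ccc(NC(=O)OCc2ccccc2)cc1` gives 27600 nM. Compound 3 `N#C[Se]c1ccc(NC(=O)Oc2ccccc2)cc1` gives 26200 nM. Compound 3 holds the lowest of the three numbers, but its gap to compound 2 and to compound 1 is within the usual scatter, so no one of the three can be called a stronger or weaker inhibitor than the others.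

Compound 4 `CC(C)COC(=O)Nc1ccc([Se]C#N)cc1` differs from compound 3 in one place: isobutyl in place of phenyl on an oxygen next to a carbonyl group. Among the compounds with values here, two measured steps bear on this change, both at the same oxygen next to the carbonyl group. Swapping the group there gave a 1.1-fold lower number from compound 1 to compound 3 (0.04 log units; within the scatter) and a 1.0-fold lower number from compound 1 to compound 2 (0.02 log units; within the scatter), both within the scatter. On this evidence the growth inhibition seems insensitive to what sits on that oxygen, so the expected step, a 1.0-fold higher number from compound 3 to compound 4 (0.02 log units; within the scatter), is none beyond the scatter. Compound 4 is therefore estimated at 27500 nM, with a range from 14000 nM to 55000 nM.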

Compound 4, concentration for 50% growth inhibition: 27100 nM
For compound 4 the middle estimate is 1.0-fold (0.01 log units) above the measured one, within the range that was stated.
By their numbers in this assay, from the lowest: compounds 3, 4, 2 and 1 (each within the scatter of the next).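

Isobutyl brings a branched chain to the oxygen next to a carbonyl group, a shape the earlier compounds did not carry, and in this assay the readings stay together: there is a 1.0-fold higher number from compound 3 to compound 4 (0.01 log units; within the scatter) and also a 1.0-fold lower number from compound 2 to compound 4 (0.01 log units; within the scatter) as well as a 1.1-fold lower number from compound 1 to compound 4 (0.03 log units; within the scatter) for the branch added to the propyl chain. Phenyl can therefore give way to isobutyl with no shift beyond the scatter, and a ring is not needed on this oxygen for the growth inhibition seen here. Straight, branched and ring-bearing groups of carbon alone now all sit within the scatter of one another at this position.

On these data alone, whether an amine, a carboxylic acid or a much longer chain on this oxygen would behave the same stays open. No other measurement here bears on why these numbers stay so close.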